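Swapping Thiophene for Methylfuran in a Cytotoxicity Series

A few compounds are considered here, and "the series" means these few. Any claim that something is new, unique, unknown or untested is made for them only; others in the source may bear on it.

Two measured compounds share one core. Compound 1 `COc1cc(N2C(N)=C(C#N)C(c3ccc(Cl)cc3Cl)C3=C2CC(C)(C)CC3=O)cc(OC)c1OC` carries a 2,4-dichlorophenyl group on a saturated ring carbon; in a functional assay on Ehrlich cells (Mus musculus) for cytotoxicity, tested at 25 ug/mL (on this read-out higher numbers stand for a stronger effect at the one concentration tested and lower numbers for a weaker effect), compound 1 gives 55%. Compound 2 `COc1cc(N2C(N)=C(C#N)C(c3cccs3)C3=C2CC(C)(C)CC3=O)cc(OC)c1OC` carries thiophen-2-yl at the same place, and in this assay compound 2 gives 10%. Within the data shown here, the only step measured so far, a number 45 percentage points lower from compound 1 to compound 2 (beyond the scatter), shows that exchanging the group on that carbon can move the read-out a long way. On the numbers at hand compound 2 stands lowest of the two.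

Compound 3 `COc1cc(N2C(N)=C(C#N)C(c3ccc(C)o3)C3=C2CC(C)(C)CC3=O)cc(OC)c1OC` is not yet measured. It differs from compound 2 in one place: 5-methylfuran-2-yl in place of thiophen-2-yl on a saturated ring carbon. Among the measured compounds shown here, the single measured step bears on this change only loosely, since it compared a dichlorinated six-membered aromatic ring with a five-membered one, whereas here one five-membered aromatic ring with one hetero atom replaces another. A small change is therefore expected, as a number 5 percentage points higher from compound 2 to compound 3 (within the scatter), with little confidence in its direction. For compound 3 in this assay the estimate is 15%, with a range from 0% to 45%.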

Compound 3, a percentage reported as activity, at one concentration (the size of the read-out at that concentration, not a potency): 31%
Compound 3: middle estimate off by 16 percentage points, on the low side; measured number inside the range.
By their numbers in this assay, from the lowest: compound 2; then compound 3; then compound 1.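

Replacing thiophen-2-yl with 5-methylfuran-2-yl gives a number 21 percentage points higher from compound 2 to compound 3 (beyond the scatter) in this assay, so at this saturated ring carbon the read-out can separate two groups that each hold one five-membered aromatic ring with 1 hetero atom. The earlier step showed only that a 2,4-dichlorophenyl group and a thiophen-2-yl group differ; this one shows that the choice within the five-membered rings matters too, although the change from 2,4-dichlorophenyl to 5-methylfuran-2-yl still gives a number 24 percentage points lower from compound 1 to compound 3 (beyond the scatter). Nothing available explains why these groups give different numbers.

The exchange swaps sulfur for oxygen and adds a methyl group at once, so the compounds shown leave open which of the two accounts for the step; a plain furan-2-yl or a 5-methylthiophen-2-yl group at the same carbon would pull them apart. Also open, going by these compounds, is whether the chlorine atoms or the six-membered ring set compound 1 apart, which an unsubstituted phenyl group would begin to test.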